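Swapping a nitrile for fluorine on compound 2

The source may hold more compounds than are shown below. What is called first, only, known or untested is meant among the compounds shown, and "the series" means these compounds.

In an assay on RPMI-8226 cells for antagonist activity at P2X purinoceptor 7 (Homo sapiens), read by calcium flux (on this read-out higher numbers stand for weaker inhibition and lower numbers for stronger inhibition), compound 2 `N#Cc1ccc2c(ccn2CCCCN2CCN(C(c3ccccc3)c3ccccc3)CC2)c1` gives 3800 nM, the higher of the two numbers measured, while compound 1 `Cc1nc2ccccc2n1CCCCN1CCN(C(c2ccccc2)c2ccccc2)CC1` gives 850 nM. Among the measured compounds shown here, the only measured step, a 4.5-fold higher number from compound 1 to compound 2 (0.65 log units; beyond the scatter), exchanges one ring system for another and so does not bear directly on the change to compound 3 `Fc1ccc2c(ccn2CCCCN2CCN(C(c3ccccc3)c3ccccc3)CC2)c1`, which is fluoro in place of cyano on an aromatic carbon. For the measured compounds named here, with no comparable step measured, compound 3 is expected to show a step of a 1.3-fold lower number from compound 2 to compound 3 (0.10 log units; within the scatter) that stays within the scatter. Compound 3 is therefore estimated at 3000 nM, with a range from 1000 nM to 9000 nM.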

Compound 3, half-maximal inhibitory concentration: 120 nM
The estimate for compound 3 lay 25-fold (1.40 log units) above the measured number, and the stated range ends above it.
By their numbers in this assay, from the lowest: compound 3; then compound 1; then compound 2.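

In this assay, the group on this aromatic carbon of the shared core turns out to matter a great deal: fluoro in place of cyano brings a 32-fold lower number from compound 2 to compound 3 (1.50 log units; beyond the scatter), a large step. The ring-system comparison also reverses, since 5-fluoro-1H-indol-1-yl in place of 2-methyl-1H-benzimidazol-1-yl gives a 7.1-fold lower number from compound 1 to compound 3 (0.85 log units; beyond the scatter), while the 5-cyano-1H-indol-1-yl group had given a higher number than that group. As far as these compounds go, whether fluoro itself is special, or cyano simply costs inhibition, stays open, and chloro, methoxy or plain hydrogen on this carbon would help separate the two. Nothing measured here explains the step.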